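The source may report more compounds than this note shows. Statements on the series, on what has been measured and on what is new or still open speak of the compounds shown alone.

Measured so far in a functional assay on the whole organism for antagonist activity, with Mus musculus as the target; a lower number here means that less compound is needed, a higher number that more compound is needed for the effect:
- compound 1 `CC(=O)N(C)CC#CCN1CCCC1`: > 10 mg/kg (a limit)
- compound 2 `COC(=O)N(C)C(C)C#CCn1ccnc1`: > 100 mg/kg (a limit)
- compound 3 `COC(=O)N(C)C(C)C#CCn1cncc1C`: 3.7 mg/kg

Among the compounds with values here, compound 3 at 3.7 mg/kg is the only compound here with a number in this assay. The other two values are limits, as the entries show: the limit of > 10 mg/kg in this assay, at which 1 of the 3 values shown sits, and (the limit of > 100 mg/kg in this assay, at which 1 of the 3 values shown sits).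

Next in the series is compound 4 `CCOC(=O)N(C)C(C)C#CCn1cncc1C`, which differs from compound 3 by a single change: methyl in place of hydrogen on a saturated chain carbon bound to an oxygen next to a carbonyl group. In words, this is methyl in place of hydrogen on a saturated chain carbon bound to an oxygen next to a carbonyl group, so that methoxycarbonyl becomes ethoxycarbonyl.

Within the data shown here, only one measured step bears on this change: an at least 27-fold lower number from compound 2 to compound 3 (1.43 log units; beyond the scatter). That step is large and also adds a methyl in place of hydrogen, but on an aromatic carbon, so it is a different place from the one changed here. It shows that a single methyl can matter in this series, but it gives neither the size nor the direction of a change in the ester chain. Among the measured compounds shown here, with no measured step at this place, the working expectation in this assay is no change beyond the scatter, with a slight lean towards a higher number. The expected step is a 1.4-fold higher number from compound 3 to compound 4 (0.13 log units; within the scatter). For compound 4 the estimated value is 5 mg/kg, with an expected range of 1.5 mg/kg to 20 mg/kg.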

Compound 4, dose for half-maximal effect: 9.7 mg/kg
Compound 4: middle estimate off by 1.9-fold (0.29 log units), on the low side, and the stated range covers the measured number.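

The step from methoxycarbonyl to ethoxycarbonyl gives a 2.6-fold higher number from compound 3 to compound 4 (0.42 log units; beyond the scatter) in this assay, so the ester chain is a place where a single added methyl already registers beyond the scatter. Set against an at least 27-fold lower number from compound 2 to compound 3 (1.43 log units; beyond the scatter) on an aromatic carbon, the methyl on the saturated chain carbon moves the number the opposite way and by a smaller step, so within these two steps the outcome of adding a methyl depends on where it sits. Nothing measured for these compounds accounts for the size or direction of the new step.

A single step at this place cannot show whether a longer chain such as propoxycarbonyl or a branched one such as isopropoxycarbonyl would raise the number further, or whether the rise stops at ethoxycarbonyl. Also open, on these data alone, are how the same change reads on a compound without the methyl on the aromatic carbon, and what happens when the ester gives way to a carboxylic acid or a simple amine at this end of the molecule.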